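Working notes: replacing hydroxy with hydrogen on compound 2

The compounds below may be only part of what the source reports. "The series", "measured", "known", "first", "only" and "open" are said of these compounds alone.

Measured in a functional assay on WHCO1 cells (Homo sapiens) for antiproliferative activity, read by MTT assay, with a stated time of 48 h; a higher number here means a weaker inhibitor, a lower number a stronger inhibitor:
- compound 1 `CCC[S+]([O-])C/C=C\SSC` gives 26000 nM
- compound 2 `C=CCSS/C=C\C[S+]([O-])CCCO` gives 38000 nM

Compound 2 at 38000 nM lies within the scatter of compound 1 at 26000 nM so the two cannot be ranked.

Compound 3 `C=CCSS/C=C\C[S+]([O-])CCC` differs from compound 2 by having hydrogen in place of hydroxy on a saturated chain carbon, three bonds along the chain from a sulfur. The 3-hydroxypropyl therefore becomes propyl.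

Among the measured compounds shown here, no measured pair isolates this change, so the expectation rests on little more than the close values of these two compounds. In this assay a slight shift towards a lower number is expected, with nothing beyond the scatter. The estimated step of a 1.5-fold lower number from compound 2 to compound 3 (0.18 log units; within the scatter) is expected to remain small. For compound 3 the estimated value is 25000 nM with an expected range of 11000 nM to 50000 nM in this series.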

Compound 3, half-maximal inhibitory concentration: 23000 nM
Compound 3: middle estimate off by 1.1-fold (0.04 log units), on the high side; the range from low to high includes it.
By their numbers in this assay, from the lowest: compounds 3, 1 and 2 (each within the scatter of the next).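

In this assay the change of 3-hydroxypropyl to propyl, hydrogen in place of hydroxy on a saturated chain carbon, three bonds along the chain from a sulfur, gives a 1.7-fold lower number from compound 2 to compound 3 (0.22 log units; within the scatter) and so cannot be told from no change at this position. Vinyl in place of hydrogen on a saturated chain carbon bound to a sulfur gives a 1.1-fold lower number from compound 1 to compound 3 (0.05 log units; within the scatter) and likewise stays unresolved, so neither single change separates these compounds in this read-out. No supporting measurement bears on either result.

On these data alone, whether an amine, a carboxylic acid or a longer chain in place of the propyl would move the number beyond the scatter remains open. Also open, as far as these compounds go, is whether either change would read the same in another compound, as each is seen in one pair only.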